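Compound 1 to compound 3: changing the amino side chain

The source may report more compounds than this note shows. Statements on the series, on what has been measured and on what is new or still open speak of the compounds shown alone.

Compound 1 (`[N-]=[N+]=N[C@H]1C[C@H](n2cnc3c(NCCCCCO)nc(N)nc32)O[C@@H]1CO`) is the starting point for this step. In an ADME assay on PBMC cells (Homo sapiens) for cytotoxicity, with a stated time of 5 days (a lower number here means a stronger inhibitor, a higher number a weaker inhibitor), compound 1 gives > 100000 nM as a limit of the assay, not a number. Compound 1 therefore stands on the limit of > 100000 nM in this assay, at which 1 of the 2 values shown sits, with no exact value behind it, so any step from it can be sized only loosely.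

Compound 2 (`[N-]=[N+]=N[C@H]1C[C@H](n2cnc3c(Cl)nc(F)nc32)O[C@@H]1CO`) gives 7200 nM in this assay as a true number, which shows that the read-out can return a value within this series.

Compound 3 (`C=CCN(C)c1nc(N)nc2c1ncn2[C@H]1C[C@H](N=[N+]=[N-])[C@@H](CO)O1`) carries one change from compound 1, namely allyl(methyl)amino in place of (5-hydroxypentyl)amino on an aromatic carbon in words allyl(methyl)amino in place of (5-hydroxypentyl)amino on an aromatic carbon, with the rest of the core unchanged. Among the compounds with values here, no measured step covers this change, so the expectation remains loose. The estimated step of an at least 1.6-fold lower number from compound 1 to compound 3 (0.22 log units; that floor lies within the scatter) is expected to be modest, either toward stronger inhibition or within the scatter. Another reading at the limit would be no surprise. For compound 3 the estimate is 60000 nM with an expected range from 18000 nM to 100000 nM in the same read-out.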

Compound 3, half-maximal inhibitory concentration: > 100000 nM
Compound 3 ended at the assay's limit (the forecaster's own chance of this, stated with the estimate: 55%); middle value at least 1.6-fold (0.22 log units) from the limit.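

In this assay compound 3 gives > 100000 nM, a limit of the assay and not a number. Compound 1 also stands at a limit, so no step can be read between compound 1 and compound 3. The compounds shown leave open whether allyl(methyl)amino in place of (5-hydroxypentyl)amino on an aromatic carbon shifts the read-out at all.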